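A few compounds are considered here, and "the series" means these few. Any claim that something is new, unique, unknown or untested is made for them only; others in the source may bear on it.

Of the compounds shown here, two sharing the core have been measured in an assay for inhibition of Polyunsaturated fatty acid 5-lipoxygenase (Homo sapiens), read by spectrophotometry, tested at 20 uM; a higher number here means more inhibition at the concentration tested (going by the name of the read-out), a lower number less inhibition. Compound 1 `O=C(/C=C/C=C/c1ccc(O)cc1)N1CCCCC1` gives 44.4% there, and compound 2 `O=C(/C=C/C=C/c1cc(O)c(O)c(O)c1)N1CCCCC1` gives 82.5%; compound 2 thus stands highest of the two, with compound 1 lower by a margin beyond the scatter. Compound 3 `O=C(/C=C/C=C/c1ccc(O)c(O)c1)N1CCCCC1` is the next case: hydrogen in place of hydroxy on an aromatic carbon. Within the data shown here, no measured pair shows this change, so the size of the step is unknown, but the gap between compound 1 and compound 2 gives a sense of the range. A loss of inhibition is expected, and the estimated step of a number 14.5 percentage points lower from compound 2 to compound 3 (beyond the scatter) is likely beyond the scatter yet smaller than that gap. In this assay compound 3 is estimated at 68%, within 50% to 86%.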

Compound 3, a percentage reported as inhibition, at one concentration (the size of the read-out at that concentration, not a potency): 82.8%
Compound 3: middle estimate off by 14.8 percentage points, on the low side; low and high end bracket the measured number.
By their numbers in this assay, from the lowest: compound 1; then compounds 2 and 3 (each within the scatter of the next).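

On this aromatic carbon, ortho to a hydroxy group, the third hydroxy adds nothing measurable in this assay: hydrogen in place of hydroxy gives a number 0.3 percentage points higher from compound 2 to compound 3 (within the scatter). The second hydroxy behaves differently, since hydroxy in place of hydrogen on an aromatic carbon gives a number 38.4 percentage points higher from compound 1 to compound 3 (beyond the scatter), so that one change spans the large gap seen earlier. No evidence on hand bears on either step. Going by these compounds, whether a methoxy group, a fluorine or an amine on this carbon would match compound 3 stays open.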